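Cytotoxicity Outlook for Compound 3 with a Terminal Acetoxymethyl

A few compounds are considered here, and "the series" means these few. Any claim that something is new, unique, unknown or untested is made for them only; others in the source may bear on it.

Measured so far:
compound 1, `CCCCCCCCCC(O)C#CC#CC(CC)OC(C)=O`: 54000 nM
compound 2, `C=CC(C#CC#CC(O)CCCCCCCCC)OC(C)=O`: 12000 nM

Going by the values given here, in an ADME assay on L6 cells (Rattus norvegicus) for cytotoxicity, read by resazurin assay (on this read-out higher numbers stand for weaker inhibition and lower numbers for stronger inhibition), compound 2 gives the lowest of the two numbers, and compound 1 stands as its only neighbour at a higher number. Among the compounds with values here, the single measured step, a 4.5-fold lower number from compound 1 to compound 2 (0.65 log units; beyond the scatter), is a modest change and concerns a different part of the molecule than the one now altered.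

Compound 3, `C=CC(C#CC#CC(O)CCCCCCCCCCOC(C)=O)OC(C)=O`, differs from compound 2 by acetoxymethyl in place of hydrogen on a saturated chain carbon, ten or more bonds along the chain from an oxygen on a saturated carbon and a triple-bonded carbon. Within the data shown here, no measured step touches this kind of change, so the one known step offers no direct guide, and the sensible expectation is no step beyond the usual scatter; the expected step is a 1.3-fold higher number from compound 2 to compound 3 (0.10 log units; within the scatter). Compound 3 is therefore estimated at 15000 nM, within a range from 5000 nM to 45000 nM.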

Compound 3, half-maximal inhibitory concentration: 58000 nM
The estimate for compound 3 lay 3.9-fold (0.59 log units) below the measured number; the measured number lies above the stated range.
By their numbers in this assay, from the lowest: compound 2; then compounds 1 and 3 (each within the scatter of the next).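

The far end of the chain is not a silent position in this assay: acetoxymethyl in place of hydrogen there gives a 4.8-fold higher number from compound 2 to compound 3 (0.68 log units; beyond the scatter) and so moves the number beyond the scatter. This step is modest, as is the earlier vinyl-for-ethyl step, a 4.5-fold lower number from compound 1 to compound 2 (0.65 log units; beyond the scatter), but the two run in opposite directions, so changes at both places in the molecule can shift this cell read-out. Nothing available bears on why the number rises at this position.

The compounds shown leave open whether this rise belongs to acetoxymethyl in particular or would also follow from a hydroxymethyl group, a carboxylic acid or an amine on the same carbon. They also leave open whether a shorter or longer chain carrying the same acetoxy ending would give a step of similar size.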